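A few compounds are considered here, and "the series" means these few. Any claim that something is new, unique, unknown or untested is made for them only; others in the source may bear on it.

Compound 1 `O=C(CCCCC1CCSS1)Nc1ccccn1` is reported in a functional assay on HO8910 cells (Homo sapiens) for inhibition, read by MTT assay, with a stated time of 24 h, tested at 10 ug/mL (a higher number here means more inhibition of growth at the concentration tested, a lower number less inhibition of growth), as "not active" (no number reported), a verbal report with no number attached, so no single value places it on the scale. Compound 2 `O=C(CCCCC1CCSS1)Nc1ccc(Cl)cn1` gives in this assay 27.5%. Compound 3 `O=C(CCCCC(S)CCS)Nc1ccccn1` differs from compound 1 by a group of 5 heavy atoms (3 carbon, 2 sulfur; no ring) in place of a group of 5 heavy atoms (3 carbon, 2 sulfur; one five-membered non-aromatic ring with 2 hetero atoms), on a saturated chain carbon, four bonds along the chain from a carbonyl carbon. For the measured compounds named here, no measured step between compounds sets the size of this change; given that compound 1 stands at "not active" (no number reported), only a small step in this assay is expected, none beyond the scatter or at most a modest rise. Compound 3 is therefore estimated to give 15% in this assay, expected within 0% to 35%.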

Compound 3, percent growth inhibition at one concentration: "not active" (no number reported)
For compound 3 the study gives words and no number; there is nothing to compare the estimate with.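

Compound 1 and compound 3 are both reported only in words in this assay, so no step can be read between them. Going by these compounds, whether the 1,3-disulfanylpropyl group alters growth inhibition at all remains open. Nothing shown bears on a cause.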